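Carboxy for hydroxymethyl on the chain: second case

The compounds below may be only part of what the source reports. "The series", "measured", "known", "first", "only" and "open" are said of these compounds alone.

Measured so far in an assay on NK92 cells for inhibition of interleukin-2 (Homo sapiens), read by AlphaScreen, with stated times of 30 min and 1 h; on this read-out higher numbers stand for weaker inhibition and lower numbers for stronger inhibition:
compound 1 `Cn1nc(Cc2nnc(SCCCCCCCC(=O)Nc3ccc(Cl)cc3Cl)n2CCCO)c2ccccc2c1=O` gives a limit of the assay, > 30000 nM.
compound 2 `Cn1nc(Cc2nnc(SCCCCCCCC(=O)Nc3ccc(Cl)cc3Cl)n2CCC(=O)O)c2ccccc2c1=O` gives 14300 nM.
compound 3 `Cn1c(Cc2nn(CCCO)c(=O)c3ccccc23)nnc1SCC(=O)Nc1ccc(Cl)cc1Cl` gives a limit of the assay, > 30000 nM.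

In this assay compound 1 sits at the limit, and the change carboxy in place of hydroxymethyl on a saturated chain carbon, two bonds along the chain from an aromatic nitrogen gives an at least 2.0-fold lower number from compound 1 to compound 2 (0.32 log units; beyond the scatter), a step whose true size is open because the limit of > 30000 nM in this assay, at which 2 of the 3 values shown sit, sets the starting point.

Compound 4 `Cn1c(Cc2nn(CCC(=O)O)c(=O)c3ccccc23)nnc1SCC(=O)Nc1ccc(Cl)cc1Cl` is not yet measured. It relates to compound 3 by carboxy in place of hydroxymethyl on a saturated chain carbon, two bonds along the chain from an aromatic nitrogen, the same change as that from compound 1 to compound 2. The difference between the core of compound 1 and the core of compound 3 is not broken down here.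

Since compound 3 is also at the limit in this assay, the expectation for compound 4 rests on the step seen from compound 1 to compound 2, an at least 2.0-fold lower number from compound 1 to compound 2 (0.32 log units; beyond the scatter), and is estimated as an at least 1.5-fold lower number from compound 3 to compound 4 (0.17 log units; that floor lies within the scatter). Compound 4 is thus expected near 20000 nM, between 6000 nM and 60000 nM, with a real chance that this assay again reports only a limit.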

Compound 4, half-maximal inhibitory concentration: > 30000 nM
Compound 4: only a limit was reported; the forecaster's own chance of this, stated with the estimate: 50%; middle value at least 1.5-fold (0.17 log units) away from the limit.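

In this assay compound 4 gives > 30000 nM, which is a limit of the assay. For the compounds shown here, no step from compound 3 to compound 4 can be read because compound 3 also stands at a limit: the limit of > 30000 nM in this assay, at which 3 of the 4 values shown sit.

On these data alone, whether carboxy in place of hydroxymethyl changes the number at all on the core of compound 3 stays open.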